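One Ring Swap on the Carbamate Nitrogen

A few compounds are considered here, and "the series" means these few. Any claim that something is new, unique, unknown or untested is made for them only; others in the source may bear on it.

Compound 1 `COc1ccc(NC(=O)Oc2cc(=O)n(CCCO)c3c2CC(C/C=C(\C)CCC=C(C)C)C(C)(C)C3)cc1`: 64.1%
Compound 2 `CC(C)=CCC/C(C)=C/CC1Cc2c(OC(=O)Nc3ccc(F)c(F)c3)cc(=O)n(CCCO)c2CC1(C)C`: 43.7%

Both compounds were tested in a functional assay on PANC-1 cells (Homo sapiens) for inhibition, read by MTT assay, with a stated time of 24 h, tested at 10 uM; a higher number here means more inhibition at the concentration tested (going by the name of the read-out), a lower number less inhibition. Among the compounds with values here, compound 2 stands lowest of the two numbers, and its only neighbour is compound 1. Within the data shown here, the one step measured so far, a number 20.4 percentage points lower from compound 1 to compound 2 (beyond the scatter), was modest yet beyond the scatter. Compound 3 `CC(C)=CCC/C(C)=C/CC1Cc2c(OC(=O)Nc3ccc(Cl)cc3)cc(=O)n(CCCO)c2CC1(C)C` differs from compound 2 by 4-chlorophenyl in place of 3,4-difluorophenyl on an amide-type nitrogen. Among the measured compounds shown here, no measured step covers an exchange of one halogenated ring for another, so the single step offers only rough guidance. A step of a number 6.3 percentage points higher from compound 2 to compound 3 (within the scatter) is expected, with compound 3 estimated at 50% (range 30% to 70%).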

Compound 3, a percentage reported as inhibition, at one concentration (the size of the read-out at that concentration, not a potency): 47.2%
For compound 3 the middle estimate is 2.8 percentage points above the measured one; low and high end bracket the measured number.
By their numbers in this assay, from the lowest: compounds 2 and 3 (each within the scatter of the next); then compound 1.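

In this assay trading one halogenated ring for another on the amide-type nitrogen gives a number 3.5 percentage points higher from compound 2 to compound 3 (within the scatter) and so separates nothing. Chloro in place of methoxy on the aromatic ring gives a number 16.9 percentage points lower from compound 1 to compound 3 (beyond the scatter) and shows that the earlier fall was not tied to fluorine: both halogenated rings read below the 4-methoxyphenyl ring of compound 1. No measurement at hand gives a reason for this difference.

As far as these compounds go, whether methoxy itself matters, or any non-halogen group would serve as well, stays open. A plain phenyl ring, or one carrying an ethoxy or dimethylamino group, would help to tell.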